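The source may hold more compounds than are shown below. What is called first, only, known or untested is meant among the compounds shown, and "the series" means these compounds.

Compound 1 `CC1CCN(c2c(S(=O)(=O)c3ccc(F)cc3)cnc3ccc(Cl)cc23)CC1`: 89%
Compound 2 `Cc1ccc(S(=O)(=O)c2cnc3ccc(Cl)cc3c2N2CCC(C)CC2)cc1Cl`: 81%

In an assay on isolated protein for displacement of a labelled ligand from metabotropic glutamate receptor 5 (Homo sapiens), with a stated time of 60 min, tested at 1 uM (on this read-out lower numbers stand for less inhibition and higher numbers for more inhibition at the one concentration tested (going by the name of the read-out)), compound 2 and compound 1 lie within the scatter of each other, the step being a number 8 percentage points lower from compound 1 to compound 2 (within the scatter). Compound 3 `CC1CCN(c2c(S(=O)(=O)c3cccc(F)c3)cnc3ccc(Cl)cc23)CC1` differs from compound 2 in one place: 3-fluorophenyl in place of 3-chloro-4-methylphenyl on a sulfonyl sulfur. Among the measured compounds shown here, the only step to draw on, a number 8 percentage points lower from compound 1 to compound 2 (within the scatter), also exchanges the aryl group on the sulfonyl sulfur and stays within the scatter, and compound 3 again carries a fluorophenyl there as compound 1 does. No step beyond the scatter is therefore expected in this assay, the expected step being a number 4 percentage points higher from compound 2 to compound 3 (within the scatter). Compound 3 is estimated at 85%, with a range of 70% to 95%.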

Compound 3, a percentage reported as inhibition, at one concentration (the size of the read-out at that concentration, not a potency): 58%
Compound 3: the middle estimate sits 27 percentage points above what was measured, outside the stated range (below it).
By their numbers in this assay, from the lowest: compound 3; then compounds 2 and 1 (each within the scatter of the next).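

In this assay the aryl group on the sulfonyl sulfur no longer looks freely exchangeable: 3-fluorophenyl in place of 4-fluorophenyl gives a number 31 percentage points lower from compound 1 to compound 3 (beyond the scatter), so the two fluorophenyl groups are not interchangeable here. 3-fluorophenyl in place of 3-chloro-4-methylphenyl gives a number 23 percentage points lower from compound 2 to compound 3 (beyond the scatter), so of that pair the number is higher with the group of compound 2. Nothing available explains either step.

Going by these compounds, it remains open whether the chlorine or the methyl carries the value of compound 2; 3-chlorophenyl and 4-methylphenyl would separate them. On these data alone, how unsubstituted phenyl compares also remains open.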